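This account rests on a few compounds, and the source may have more. Where it says the series, first, only, none or still open, it means among the compounds named here.

Compound 1 `CC#CC(CC(=O)O)c1ccc(OCc2ccc3nc(-c4ccc(C)cc4C)cn3c2)cc1`: 316 nM
Compound 2 `CC#CC(CC(=O)O)c1ccc(OCc2ccc3nc(-c4ccccc4)cn3c2)cc1`: 979 nM
Compound 3 `CC#CC(CC(=O)O)c1ccc(OCc2ccc3nc(-c4cccc(C)c4)cn3c2)cc1`: 1050 nM

In an assay on isolated protein for agonist activity at Free fatty acid receptor 1 (Homo sapiens) (on this read-out lower numbers stand for an effect already at smaller amounts and higher numbers for an effect only at larger amounts of compound), compound 3 gives the highest of the three numbers; the gap to compound 2 is within the scatter, whereas compound 1 lies clearly lower. Compound 4 `CC#CC(CC(=O)O)c1ccc(OCc2ccc3nc(-c4ccccc4F)cn3c2)cc1` differs from compound 3 by 2-fluorophenyl in place of 3-methylphenyl on an aromatic carbon. Among the measured compounds shown here, no measured step replaces a methyl with a fluorine on this ring. a 1.1-fold higher number from compound 2 to compound 3 (0.03 log units; within the scatter) shows that one methyl on this ring changes little; a 3.3-fold higher number from compound 1 to compound 3 (0.52 log units; beyond the scatter) and a 3.1-fold higher number from compound 1 to compound 2 (0.49 log units; beyond the scatter) show that 2,4-dimethylphenyl gives a markedly lower number than either phenyl or 3-methylphenyl. A single small substituent on this ring is therefore expected to leave this assay within the scatter or lower it only slightly, so a step of a 1.5-fold lower number from compound 3 to compound 4 (0.18 log units; within the scatter) is expected. Compound 4 is estimated at 700 nM, range 300 nM to 1600 nM.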

Compound 4, half-maximal effective concentration: 583 nM
The estimate for compound 4 lay 1.2-fold (0.08 log units) above the measured number; the measured number falls inside the stated range.
By their numbers in this assay, from the lowest: compounds 1, 4, 2 and 3 (each within the scatter of the next, the first and the last beyond it).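

In this assay, fluoro in place of hydrogen gives a 1.7-fold lower number from compound 2 to compound 4 (0.23 log units; within the scatter), so a single fluoro on this ring, like the single methyl, does not move the read-out beyond the scatter. The exchange of 3-methylphenyl for 2-fluorophenyl gives a 1.8-fold lower number from compound 3 to compound 4 (0.26 log units; within the scatter), again inside the scatter. Unlike compound 2 and compound 3, compound 4 is not separated from the 2,4-dimethylphenyl member, with a 1.8-fold higher number from compound 1 to compound 4 (0.27 log units; within the scatter) as the step. No supporting data bear on these steps. Open, from the compounds shown here alone, is whether an amine, a methoxy group or a longer chain on this ring would separate from phenyl.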